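Adding a Methoxy Group to Compound 2

The source may report more compounds than this note shows. Statements on the series, on what has been measured and on what is new or still open speak of the compounds shown alone.

Compound 1 `COc1ccccc1C(=O)n1c(-c2cn(C)c3ccccc23)nc2ccccc21` gives 32100 nM
Compound 2 `Cn1cc(-c2nc3ccccc3n2C(=O)c2ccccc2)c2cc(Br)ccc21` gives 50300 nM

In a functional assay on MCF7 cells (Homo sapiens) for inhibition, read by MTT assay, with a stated time of 24 h (on this read-out higher numbers stand for weaker inhibition of growth and lower numbers for stronger inhibition of growth), compound 2 stands within the usual scatter of compound 1, so these two values show no real order. The change from compound 2 to compound 3 `COc1ccccc1C(=O)n1c(-c2cn(C)c3ccc(Br)cc23)nc2ccccc21` is methoxy in place of hydrogen on an aromatic carbon in a single place: methoxy in place of hydrogen on an aromatic carbon. Among the measured compounds shown here, no measured pair shows this change alone, so no step beyond the scatter is expected, in either direction. The estimate is a 1.3-fold lower number from compound 2 to compound 3 (0.12 log units; within the scatter) and is expected to stay within the scatter. Compound 3 is expected at 38000 nM (15000 nM to 90000 nM).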

Compound 3, concentration for 50% growth inhibition: 36200 nM
For compound 3 the middle estimate is 1.0-fold (0.02 log units) above the measured one; measured number inside the range.
By their numbers in this assay, from the lowest: compounds 1, 3 and 2 (each within the scatter of the next).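

In this assay the change from benzoyl to (2-methoxyphenyl)carbonyl, ortho to a large group, gives a 1.4-fold lower number from compound 2 to compound 3 (0.14 log units; within the scatter) and so does not separate the two compounds. With methoxy already in place, bromo in place of hydrogen on an aromatic carbon gives a 1.1-fold higher number from compound 1 to compound 3 (0.05 log units; within the scatter) and so this change does not separate its two compounds either. Nothing measured here bears on why these numbers fall as they do. On these data alone, whether a different group at the methoxy place, such as an amine or a carboxylic acid, would give a step beyond the scatter remains open.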